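Heteroaryl amides against nicotinamide phosphoribosyltransferase: compound 4

The source may hold more compounds than are shown below. What is called first, only, known or untested is meant among the compounds shown, and "the series" means these compounds.

Measured so far, in an assay for inhibition of Nicotinamide phosphoribosyltransferase (Homo sapiens), read by mass spectrometry, with stated times of 15 min and 30 min; on this read-out higher numbers stand for weaker inhibition and lower numbers for stronger inhibition:
compound 1, `O=C(NCc1ccc(S(=O)(=O)c2ccccc2)cc1)c1nc2cnccc2[nH]1`, gives 7100 nM
compound 2, `O=C(NCc1ccc(S(=O)(=O)c2ccccc2)cc1)c1cc2ccncc2s1`, gives 7 nM
compound 3, `O=C(NCc1ccc(S(=O)(=O)c2ccccc2)cc1)c1ccc2nccn2c1`, gives 18 nM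

Compound 3 holds the second highest of the three numbers in this assay, with compound 2 below it and compound 1 far above it. Compound 4, `O=C(NCc1ccc(S(=O)(=O)c2ccccc2)cc1)c1c[nH]c2ccncc12`, carries the same atoms joined differently: a group of 9 heavy atoms (7 carbon, 2 nitrogen; one five-membered aromatic ring with 1 hetero atom, one six-membered aromatic ring with 1 hetero atom) in place of a group of 9 heavy atoms (7 carbon, 2 nitrogen; one five-membered aromatic ring with 2 hetero atoms, one six-membered aromatic ring with 1 hetero atom), on a carbonyl carbon. Every step measured so far also swaps the bicyclic group on this carbonyl carbon, and these steps span a wide range: a 390-fold lower number from compound 1 to compound 3 (2.60 log units; beyond the scatter), a 1000-fold lower number from compound 1 to compound 2 (3.01 log units; beyond the scatter), while a 2.6-fold higher number from compound 2 to compound 3 (0.41 log units; beyond the scatter). Since both groups of compound 3 and compound 4 share their atom count, a modest step is expected, as in the step from compound 2 to compound 3, with direction uncertain. Compound 4 is therefore estimated at 40 nM, between 8 nM and 200 nM, which would mean a 2.2-fold higher number from compound 3 to compound 4 (0.35 log units; beyond the scatter).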

Compound 4, half-maximal inhibitory concentration: 1900 nM
For compound 4 the middle estimate is 48-fold (1.68 log units) below the measured one; the measured number lies above the stated range.
By their numbers in this assay, from the lowest: compound 2; then compound 3; then compound 4; then compound 1.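

In this assay the group on the carbonyl carbon proves highly sensitive to how the same atoms are joined, giving a 110-fold higher number from compound 3 to compound 4 (2.02 log units; beyond the scatter) despite the matching atom count between these two compounds. Alongside this stands a 270-fold higher number from compound 2 to compound 4 (2.43 log units; beyond the scatter). Compound 4 falls much nearer compound 1, with a 3.7-fold lower number from compound 1 to compound 4 (0.57 log units; beyond the scatter) remaining. The entering group has a hydrogen-bond donor where the leaving group has none, but nothing here accounts for the loss. The compounds shown leave open whether a methyl group on that donor nitrogen would restore the low numbers of compound 2 and compound 3.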